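From methoxy to trifluoromethyl: the step to compound 4

The source may hold more compounds than are shown below. What is called first, only, known or untested is meant among the compounds shown, and "the series" means these compounds.

Measured in an ADME assay on HT-29 cells (Homo sapiens) for inhibition, read by trypan blue exclusion, with a stated time of 72 h; on this read-out higher numbers stand for weaker inhibition of growth and lower numbers for stronger inhibition of growth:
Compound 1 `O=C(/C=C/c1ccccc1)c1cccc([N+](=O)[O-])c1`: 9000 nM
Compound 2 `COc1cccc(C(=O)/C=C/c2ccccc2)c1`: 14700 nM
Compound 3 `O=C(/C=C/c1ccccc1)c1ccc(C(F)(F)F)cc1`: > 20000 nM (a limit of the assay)

Compound 2, at 14700 nM, has only compound 1 as a neighbour with a number, and the two lie within the scatter of each other. Compound 3, which also carries trifluoromethyl, gives only a limit. Compound 4 `O=C(/C=C/c1ccccc1)c1cccc(C(F)(F)F)c1` has trifluoromethyl in place of methoxy on an aromatic carbon, meta to a large group: trifluoromethyl in place of methoxy on an aromatic carbon. Within the data shown here, the one measured step at this place is a 1.6-fold higher number from compound 1 to compound 2 (0.21 log units; within the scatter), methoxy in place of nitro, so no change beyond the scatter is expected in this assay. The estimated step is a 1.0-fold higher number from compound 2 to compound 4 (0.01 log units; within the scatter). For compound 4 the estimate is 15000 nM, with an expected range from 7500 nM to 28000 nM.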

Compound 4, concentration for 50% growth inhibition: > 20000 nM
Compound 4: no number, only a limit; the forecaster's own chance of this, stated with the estimate: 35%; at least 1.3-fold (0.12 log units) between middle value and limit.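

In this assay compound 4 gives only a limit, > 20000 nM. Trifluoromethyl in place of nitro gives an at least 2.2-fold higher number from compound 1 to compound 4 (0.34 log units; beyond the scatter), the first step at this position that clears the scatter, while trifluoromethyl in place of methoxy gives an at least 1.3-fold higher number from compound 2 to compound 4 (0.13 log units; that floor lies within the scatter), so that floor does not separate these two groups. Both steps are floors, as the reading stops at the limit: the limit of > 20000 nM in this assay, at which 2 of the 4 values shown sit.

From the compounds shown here alone, the actual size of both steps remains open. So does how an amine or a carboxylic acid on this aromatic carbon would read.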